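The source may hold more compounds than are shown below. What is called first, only, known or untested is meant among the compounds shown, and "the series" means these compounds.

- compound 1 `Nc1cc(OCCNc2ccnc3cc(Cl)ccc23)nc(N)n1`: 300 nM
- compound 2 `Nc1cc(OCCCNc2ccnc3cc(Cl)ccc23)nc(N)n1`: 310 nM
- compound 3 `Nc1cc(OCCOCCNc2ccnc3cc(Cl)ccc23)nc(N)n1`: 1170 nM

In a physicochemical assay for solubility, read by HPLC, in phosphate buffer, with a stated time of 24 h, at 37 degrees C, at pH 5.5 (a higher number here means a more soluble compound, a lower number a less soluble compound), compound 1 gives 300 nM, and compound 2 gives 310 nM, the two lying within the scatter of each other. Compound 3, at 1170 nM, stands higher than compound 1, beyond the scatter.

The next compound to read is compound 4 `CCC(COc1cc(N)nc(N)n1)Nc1ccnc2cc(Cl)ccc12`. It carries ethyl in place of hydrogen on a saturated chain carbon bound to a nitrogen on an aromatic ring and a saturated chain carbon. Going by the values given here, no measured pair isolates a change of this kind, so the expectation carries wide uncertainty. In this assay a small downward step is expected, probably none beyond the scatter. The expected change is a 1.5-fold lower number from compound 1 to compound 4 (0.18 log units; within the scatter). For compound 4 the estimated value is 200 nM, with an expected range of 70 nM to 550 nM.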

Compound 4, solubility: 40 nM
Compound 4: the middle estimate sits 5.0-fold (0.70 log units) above what was measured; measured number outside the range, below it.
By their numbers in this assay, from the lowest: compound 4; then compounds 1 and 2 (each within the scatter of the next); then compound 3.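

In this assay, ethyl in place of hydrogen on a saturated chain carbon bound to a nitrogen on an aromatic ring and a saturated chain carbon gives a 7.5-fold lower number from compound 1 to compound 4 (0.88 log units; beyond the scatter) and this step lies beyond the scatter. Going by these compounds alone, it is the first step that isolates a single change, and it shows that this chain carbon does not tolerate the added ethyl without a clear fall in the read-out. No measurement shown bears on why the number falls.

From the compounds shown here alone, whether methyl or a longer chain on this carbon gives a step of similar size remains open, as does the effect of an amine there. Also open, going by these compounds, is whether ethyl has the same effect on the chains of compound 2 and compound 3, since the step is read on the chain of compound 1 alone.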